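The source may report more compounds than this note shows. Statements on the series, on what has been measured and on what is new or still open speak of the compounds shown alone.

Compound 1 `COCCOc1nc(N)nc2c1ncn2/C=C1/CC1(CO)CO` and compound 3 `Nc1nc2c(ncn2/C=C2/CC2(CO)CO)c(=O)[nH]1` share their core with compound 2 `Nc1nc(OCc2ccccc2)c2ncn(/C=C3/CC3(CO)CO)c2n1`. In an ADME assay on HFF cells (Homo sapiens) for cytotoxicity, with a stated time of 8 days (on this read-out lower numbers stand for higher toxicity in this test and higher numbers for lower toxicity in this test), compound 1 gives only a limit of the assay, > 300000 nM. Compound 3 likewise reaches only a limit in this assay, > 300000 nM. Compound 2 too stands at a limit in this assay, > 300000 nM. Going by the values given here, the one measured step, a step that the two limits leave unreadable from compound 1 to compound 2, stays unreadable, since the limit of > 300000 nM in this assay, at which 3 of the 3 values shown sit, holds every value shown. Compound 4 `Nc1nc(NC2CCCCC2)c2ncn(/C=C3/CC3(CO)CO)c2n1` differs from compound 2 by cyclohexylamino in place of benzyloxy on an aromatic carbon. Among the compounds with values here, no measured step bears on this change, and nothing among the measured compounds points away from the limit. The step is therefore estimated as a step that the limit leaves unreadable from compound 2 to compound 4, none beyond the scatter. Compound 4 is expected to give 400000 nM in this assay, between 150000 nM and 1000000 nM, most likely reported once more as a limit.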

Compound 4, half-maximal cytotoxic concentration: > 300000 nM
Compound 4: no number, only a limit; the forecaster's own chance of this, stated with the estimate: 85%; the middle value lies beyond the limit too.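

Compound 4, like compound 1 and compound 2, stands only at a limit, so no step among these compounds can be read: the limit of > 300000 nM in this assay, at which 4 of the 4 values shown sit.

The compounds shown leave open whether any group on this aromatic carbon of the shared core would change the read-out in this assay.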